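Moving the hydroxyl group to the 4-hydroxyphenyl compound

This account rests on a few compounds, and the source may have more. Where it says the series, first, only, none or still open, it means among the compounds named here.

- compound 1 `COc1cc(C2CC(=NOC(=O)c3ccc(Cl)cc3)CC(c3ccc(O)c(OC)c3)N2C)ccc1O` gives 121000 nM
- compound 2 `COc1cc(C2CC(=NOC(=O)c3cccc(O)c3)CC(c3ccc(O)c(OC)c3)N2C)ccc1O` gives 25300 nM
- compound 3 `COc1cc(C2CC(=NOC(=O)c3ccccc3O)CC(c3ccc(O)c(OC)c3)N2C)ccc1O` gives 24100 nM

All three values come from a functional assay on microsomes from liver (Rattus norvegicus, strain Wistar) for inhibition, read by spectrophotometry, with a stated time of 60 min; on this read-out higher numbers stand for weaker inhibition and lower numbers for stronger inhibition. Compound 3 shares the low end of these numbers with the 3-hydroxyphenyl compound: a 1.0-fold lower number from compound 2 to compound 3 (0.02 log units; within the scatter). The 4-chlorophenyl compound gives a higher number: a 5.0-fold lower number from compound 1 to compound 3 (0.70 log units; beyond the scatter), and likewise a 4.8-fold lower number from compound 1 to compound 2 (0.68 log units; beyond the scatter).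

Compound 4 `COc1cc(C2CC(=NOC(=O)c3ccc(O)cc3)CC(c3ccc(O)c(OC)c3)N2C)ccc1O` carries one change: 4-hydroxyphenyl in place of 2-hydroxyphenyl on a carbonyl carbon. The closest measured precedent is the exchange of one hydroxyphenyl for another, a 1.0-fold lower number from compound 2 to compound 3 (0.02 log units; within the scatter), which stayed within the scatter. The two modest steps both involve losing the 4-chlorophenyl and are a weaker guide here. The estimate is a 1.2-fold higher number from compound 3 to compound 4 (0.10 log units; within the scatter), so no step beyond the scatter is expected. For compound 4 the expected value is 30000 nM, with an estimated range of 13000 nM to 70000 nM.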

Compound 4, half-maximal inhibitory concentration: 22500 nM
For compound 4 the middle estimate is 1.3-fold (0.12 log units) above the measured one; measured number inside the range.
By their numbers in this assay, from the lowest: compounds 4, 3 and 2 (each within the scatter of the next); then compound 1.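

Among the hydroxyphenyl compounds, the site of the hydroxyl on the ring makes no difference that can be read: the change from 2-hydroxyphenyl to 4-hydroxyphenyl stays within the scatter (a 1.1-fold lower number from compound 3 to compound 4 (0.03 log units; within the scatter)), as does the change from 3-hydroxyphenyl to 4-hydroxyphenyl (a 1.1-fold lower number from compound 2 to compound 4 (0.05 log units; within the scatter)). The exchange of hydroxy for chloro on an aromatic carbon can now be read directly, and it lies beyond the scatter (a 5.4-fold lower number from compound 1 to compound 4 (0.73 log units; beyond the scatter)). Nothing available here explains these numbers.

On these data alone, whether an amine or a carboxylic acid on this ring, or a longer chain in its place, would move the number away from the hydroxyphenyl compounds stays open.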